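Swapping One Side Group on a Shared Core

This account rests on a few compounds, and the source may have more. Where it says the series, first, only, none or still open, it means among the compounds named here.

Among the compounds with values here, in an ADME assay on microsomes from liver (Homo sapiens) for metabolic stability, with a stated time of 10 min, tested at 0.5 uM (a higher number here means that more of the compound is left, a lower number that less of the compound is left), compound 1 `C[C@@H](CNc1ccc(Cl)cc1)[C@H]1CC[C@@H](c2ccnc3ccc(F)cc32)CC1` gives 80%, the higher of the two numbers so far. Compound 2 `C[C@@H](c1nc2ccc(Cl)cc2[nH]1)[C@H]1CC[C@@H](c2ccnc3ccc(F)cc32)CC1` gives 48%, and the gap between the two lies beyond the usual scatter. Both compounds share their core with compound 3 `C[C@@H](NC(=O)C1CCCCC1)[C@H]1CC[C@@H](c2ccnc3ccc(F)cc32)CC1`, which has not yet been measured. Compound 3 carries (cyclohexylcarbonyl)amino in place of ((4-chlorophenyl)amino)methyl on a saturated chain carbon bound to a saturated chain carbon and a saturated ring carbon. Within the data shown here, no measured pair shows this kind of swap, so the expectation is only rough. The two measured compounds show that the amount left can differ widely on this core. A moderate fall in this assay is expected, a number 18 percentage points lower from compound 1 to compound 3 (beyond the scatter), though a change within the scatter remains possible. For compound 3 the estimated value is 62%, with an expected range from 38% to 84%.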

Compound 3, percent of the compound remaining: 6%
Compound 3: the middle estimate sits 56 percentage points above what was measured; measured number outside the range, below it.
By their numbers in this assay, from the lowest: compound 3; then compound 2; then compound 1.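

In this assay, within the data shown here, swapping the one side group that sets these two compounds apart gives a number 74 percentage points lower from compound 1 to compound 3 (beyond the scatter). The two groups have matching counts of heavy atoms, hydrogen-bond donors and hydrogen-bond acceptors, and neither carries a net charge, so these counts alone do not track the amount left at this position. Nothing measured here explains the drop.

Going by these compounds, this single swap changes several things together: an aromatic ring becomes a non-aromatic one, the chlorine is gone, and a carbonyl enters, so the part that matters stays open. A (4-chlorobenzoyl)amino group, which pairs the carbonyl link with the chlorinated aromatic ring, would help separate the ring from the link.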